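A few compounds are considered here, and "the series" means these few. Any claim that something is new, unique, unknown or untested is made for them only; others in the source may bear on it.

In an ADME assay on microsomes from liver (Homo sapiens) for metabolic stability, read by LC-MS, using NADPH, with a stated time of 45 min, tested at 3 uM (on this read-out higher numbers stand for a longer-lived compound and lower numbers for a shorter-lived compound), compound 1 (`C1CCC(C(CC2CCCCN2)C2CCC2)CC1`) gives > 3.33 h, which is a limit of the assay and not a number. Within the data shown here, compound 2 (`Fc1ccc(C(CC2CCCCN2)C2CCCCC2)cc1`) gives 1.32 h, the only actual number so far. Compound 3 (`FC1CCC(C(CC2CCCCN2)C2CCCCC2)CC1`) carries 4-fluorocyclohexyl in place of 4-fluorophenyl on a saturated chain carbon bound to a saturated chain carbon and a saturated ring carbon. Among the measured compounds shown here, one measured step bears on this change, namely an at least 2.5-fold lower number from compound 1 to compound 2 (0.40 log units; beyond the scatter), in which 4-fluorophenyl came in and the half-life fell beyond the scatter. That step rests on (the limit of > 3.33 h in this assay, at which 1 of the 2 values shown sits). With 4-fluorophenyl now leaving, a modest rise in this assay is expected, in the opposite direction to an at least 2.5-fold lower number from compound 1 to compound 2 (0.40 log units; beyond the scatter). The estimated step is a 2.0-fold higher number from compound 2 to compound 3 (0.29 log units; within the scatter). Compound 3 is expected to give 2.6 h, within an estimated range of 1.2 h to 5.5 h.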

Compound 3, half-life: 1.08 h
Compound 3: the middle estimate sits 2.4-fold (0.38 log units) above what was measured; measured number below the stated range.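

In this assay, the change at this place, on a saturated chain carbon bound to a saturated chain carbon and a saturated ring carbon, gives a 1.2-fold lower number from compound 2 to compound 3 (0.09 log units; within the scatter), so exchanging the aromatic ring of 4-fluorophenyl for the non-aromatic ring of 4-fluorocyclohexyl leaves the half-life within the scatter. Set against cyclobutyl at the same place, 4-fluorocyclohexyl gives an at least 3.0-fold lower number from compound 1 to compound 3 (0.48 log units; beyond the scatter), a step beyond the scatter, as the one to 4-fluorophenyl was, so the aromatic ring alone does not account for that earlier step. For compound 1, the value of > 3.33 h is a limit of the assay and not a number, and both steps rest on it: the limit of > 3.33 h in this assay, at which 1 of the 3 values shown sits.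

The compounds shown leave open what the fluorine contributes on either ring. They also leave open how a pyridine ring, a morpholine or a cyclopentyl group would behave at this place.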